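Cytotoxicity notes on a fused-bicyclic aminopyrimidine series

A few compounds are considered here, and "the series" means these few. Any claim that something is new, unique, unknown or untested is made for them only; others in the source may bear on it.

Measured so far, in an ADME assay on cells (Homo sapiens) for cytotoxicity, read by polymerase chain reaction, with a stated time of 3 days; on this read-out higher numbers stand for lower toxicity in this test and lower numbers for higher toxicity in this test:
- compound 1 `Cc1nc(N[C@H](C)c2ccccc2)nc(N[C@@H]2C[C@H](CO)[C@@H](O)[C@H]2O)c1-c1nc2cnccc2s1` gives 25000 nM
- compound 2 `Cc1ccc([C@@H](C)Nc2nc(C)c(-c3nc4cnccc4s3)c(N[C@@H]3C[C@H](CO)[C@@H](O)[C@H]3O)n2)cc1` gives 25000 nM
- compound 3 `Cc1cc2sc(-c3c(C)nc(N[C@H](C)c4ccc(OC(F)(F)F)cc4)nc3N[C@@H]3C[C@H](CO)[C@@H](O)[C@H]3O)nc2cn1` gives 25000 nM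

Compound 1 and compound 2 differ by methyl in place of hydrogen on an aromatic carbon, and this gave no change at the digits printed from compound 1 to compound 2 (within the scatter). Compound 3 stands level with both at the digits recorded; how its core differs from that of compound 1 is not broken down here.

Compound 4 `Cc1cc2sc(-c3c(C)nc(N[C@H](C)c4ccc(OC(F)(F)F)cc4)nc3N[C@@H]3C[C@H](CO)[C@@H](O)[C@H]3O)nc2c(C)n1` is not yet measured. It differs from compound 3 by methyl in place of hydrogen on an aromatic carbon. This is the same kind of change as from compound 1 to compound 2, but not the same: there the place was on a six-membered aromatic ring of carbon only, para to a large group; here it is on a six-membered aromatic ring with one nitrogen, part of a fused system of two rings, next to the ring nitrogen.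

In this assay compound 4 is expected to show no change at the digits printed from compound 3 to compound 4 (within the scatter), resting on the flat result of no change at the digits printed from compound 1 to compound 2 (within the scatter) and on compound 3 at 25000 nM. The estimate for compound 4 is 25000 nM, between 12000 nM and 50000 nM.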

Compound 4, half-maximal cytotoxic concentration: 20000 nM
Estimate against measurement, compound 4: 1.3-fold (0.10 log units) above; the measured number falls inside the stated range.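

In this assay, methyl in place of hydrogen on an aromatic carbon gives a 1.3-fold lower number from compound 3 to compound 4 (0.10 log units; within the scatter), and the two cores agree on this change: the same change on two cores in this assay, no change at the digits printed (within the scatter) from compound 1 to compound 2 and a 1.3-fold lower number (0.10 log units; within the scatter) from compound 3 to compound 4, 1.3-fold (0.10 log units) apart, within the scatter of two such steps. In this read-out, the swap therefore carries from one core to the other with no step beyond the scatter, at the two places tested. This rests on two pairs only, with the methyl on a different ring in each, so it does not show that the same would hold at other places or on a further core.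

The compounds shown leave open whether an ethyl group, a methoxy group or an amine at the place next to the ring nitrogen would move the number in this assay beyond the scatter from compound 3.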